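A few compounds are considered here, and "the series" means these few. Any claim that something is new, unique, unknown or untested is made for them only; others in the source may bear on it.

In a functional assay on A549 cells (Homo sapiens) for inhibition, read by sulforhodamine B assay (a lower number here means a stronger inhibitor of growth, a higher number a weaker inhibitor of growth), compound 3 `Oc1ccc(-c2ccc(-c3ccc(-c4nc5c(O)cccc5[nH]4)cc3)cc2)cc1` gives 170 nM, level with compound 2 `Oc1cccc2[nH]c(-c3ccc(-c4ccc(-c5ccc(F)cc5)cc4)cc3)nc12` at 170 nM. Within the data shown here, those two share the lowest number so far, while compound 1 `Cc1ccc2[nH]c(-c3ccc(-c4ccc(-c5ccc(N(C)C)cc5)cc4)cc3)nc2c1` reads 3510 nM, a far higher number than either.

The next change, leading to compound 4 `CN(C)c1ccc(-c2ccc(-c3ccc(-c4nc5c(O)cccc5[nH]4)cc3)cc2)cc1`, puts dimethylamino in place of hydroxy on an aromatic carbon, para to a large group: dimethylamino in place of hydroxy on an aromatic carbon. The closest evidence is the swap at that same spot, no change at the digits printed from compound 2 to compound 3 (within the scatter), where hydroxy replaced fluoro and the number stayed within the scatter. That swap suggests the spot can take more than one small group, but dimethylamino is larger than either. Compound 1 already carries the 4-(dimethylamino)phenyl end and reads 3510 nM, yet its core differs from that of compound 3, so that value cannot be pinned on this group alone.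

A modest rise in this assay is the expected outcome, and the estimated step is a 2.1-fold higher number from compound 3 to compound 4 (0.31 log units; beyond the scatter). For compound 4, the estimate is 350 nM, with an expected range of 110 nM to 1500 nM.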

Compound 4, concentration for 50% growth inhibition: 7100 nM
For compound 4 the middle estimate is 20-fold (1.31 log units) below the measured one, and the stated range ends below it.
By their numbers in this assay, from the lowest: compounds 2 and 3 (each within the scatter of the next); then compound 1; then compound 4.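

In this assay, the earlier swap between fluoro and hydroxy left the number in place, but this position does not accept every group: dimethylamino gives a 42-fold higher number from compound 3 to compound 4 (1.62 log units; beyond the scatter), and the comparison with fluoro gives a 42-fold higher number from compound 2 to compound 4 (1.62 log units; beyond the scatter). With the 4-(dimethylamino)phenyl end held constant, 4-hydroxy-1H-benzimidazol-2-yl in place of 5-methyl-1H-benzimidazol-2-yl gives a 2.0-fold higher number from compound 1 to compound 4 (0.31 log units; beyond the scatter), so the 4-hydroxy-1H-benzimidazol-2-yl group does not restore the low numbers seen with fluoro or hydroxy at the far end. Nothing available explains why dimethylamino raises the number so sharply.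

The compounds shown leave open whether this rise is specific to dimethylamino or would also appear with a plain amino group or a methoxy group at this position. They also leave open how hydroxy or fluoro would read when paired with the 5-methyl-1H-benzimidazol-2-yl end.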